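Sulfonyl-benzimidazole pyrazoles: hepatocyte tolerance notes

The compounds below may be only part of what the source reports. "The series", "measured", "known", "first", "only" and "open" are said of these compounds alone.

Compound 1 `O=S(=O)(c1ccccc1)n1c(-c2cn(-c3ccccc3)nc2-c2ccc(F)cc2)nc2ccccc21` gives 231000 nM in an ADME assay on cells (Hepatocyte, Mus musculus) for cytotoxicity, read by MTT assay, with a stated time of 24 h; a higher number here means that more compound is tolerated, a lower number that less compound is tolerated. Compound 2 `O=S(=O)(c1ccc(F)cc1)n1c(-c2cn(-c3ccccc3)nc2-c2ccc(F)cc2)nc2ccccc21` gives 174000 nM, and compound 3 `O=S(=O)(c1ccc(C(F)(F)F)cc1)n1c(-c2cn(-c3ccccc3)nc2-c2ccc(F)cc2)nc2ccccc21` gives 55300 nM. The step of a 1.3-fold lower number from compound 1 to compound 2 (0.12 log units; within the scatter) stays small, while a 4.2-fold lower number from compound 1 to compound 3 (0.62 log units; beyond the scatter) and a 3.1-fold lower number from compound 2 to compound 3 (0.50 log units; beyond the scatter) are the larger moves in the set. The change from compound 2 to compound 3 is trifluoromethyl in place of fluoro on an aromatic carbon. Compound 4 `O=S(=O)(c1ccccc1)n1c(-c2cn(-c3ccccc3)nc2-c2ccc(C(F)(F)F)cc2)nc2ccccc21` carries the same change relative to compound 1, (trifluoromethyl in place of fluoro on an aromatic carbon), on a core that differs from that of compound 2 by hydrogen in place of fluoro on an aromatic carbon. For the measured compounds named here, with only one measured instance of this change, the expectation for compound 4 rests on the step from compound 2 to compound 3 a 3.1-fold lower number from compound 2 to compound 3 (0.50 log units; beyond the scatter) and on compound 1 standing at 231000 nM. For compound 4 a step of similar size is expected, a 2.9-fold lower number from compound 1 to compound 4 (0.46 log units; beyond the scatter). Compound 4 is therefore estimated at 80000 nM, with a likely range from 35000 nM to 200000 nM.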

Compound 4, half-maximal cytotoxic concentration: 186000 nM
Compound 4: the middle estimate sits 2.3-fold (0.37 log units) below what was measured; low and high end bracket the measured number.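

In this assay, trifluoromethyl in place of fluoro gives a 1.2-fold lower number from compound 1 to compound 4 (0.09 log units; within the scatter). Set beside the earlier instance of this change, the result does not separate the two cores: the same change on two cores in this assay, a 3.1-fold lower number (0.50 log units; beyond the scatter) from compound 2 to compound 3 and a 1.2-fold lower number (0.09 log units; within the scatter) from compound 1 to compound 4, 2.5-fold (0.40 log units) apart, within the scatter of two such steps. This gives no sign that the core alters the step, but two instances fix no reliable size for it and do not show that it would carry to a further core.

The compounds shown carry only hydrogen, fluoro or trifluoromethyl at the places that vary, so the effect of an amine or a carboxylic acid there remains open. Also open, going by these compounds, is how a longer chain in place of trifluoromethyl would read in this assay.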